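The compounds below may be only part of what the source reports. "The series", "measured", "known", "first", "only" and "open" are said of these compounds alone.

Measured so far in a functional assay on HeLa cells (Homo sapiens) for antiproliferative activity, read by sulforhodamine B assay, with a stated time of 48 h; a lower number here means a stronger inhibitor, a higher number a weaker inhibitor:
compound 1 `COc1cc(C(=O)/C=C\Nc2ccc(-c3nc4cc(OC)c(OC)c(OC)c4s3)cc2C)cc(OC)c1OC` gives 11100 nM
compound 2 `COc1cc(OC)c2sc(-c3ccc(N/C=C\C(=O)c4cc(OC)c(OC)c(OC)c4)c(C)c3)nc2c1` gives 16400 nM

Going by the values given here, compound 1 has the lowest of the two numbers in this assay; its nearest neighbour is compound 2, and the only measured step, a 1.5-fold higher number from compound 1 to compound 2 (0.17 log units; within the scatter), lies within the scatter. Compound 3 `COc1cc(C(=O)/C=C\Nc2ccc(-c3nc4cc(OC)c(OC)c(OC)c4s3)cc2)cc(OC)c1OC` differs from compound 1 by hydrogen in place of methyl on an aromatic carbon, the change sitting on an aromatic carbon of a six-membered aromatic ring of carbon only, ortho to a large group and meta to a large group. Among the compounds with values here, no measured step removes a methyl, so the one step known, from compound 1 to compound 2, bears on it only loosely: one small substituent leaving the shared core moved the number little. On that basis the step from compound 1 to compound 3 is expected to be small, a 1.2-fold higher number from compound 1 to compound 3 (0.07 log units; within the scatter), with no direction beyond the scatter. Compound 3 is therefore estimated at 13000 nM in this assay, within 5000 nM to 35000 nM.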

Compound 3, half-maximal inhibitory concentration: 5300 nM
Compound 3: the middle estimate sits 2.5-fold (0.39 log units) above what was measured, and the stated range covers the measured number.
By their numbers in this assay, from the lowest: compound 3; then compounds 1 and 2 (each within the scatter of the next).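

In this assay, going by these compounds alone, hydrogen in place of methyl on this aromatic carbon, ortho to a large group and meta to a large group, gives the first step that lies beyond the scatter: a 2.1-fold lower number from compound 1 to compound 3 (0.32 log units; beyond the scatter). The only earlier step, a 1.5-fold higher number from compound 1 to compound 2 (0.17 log units; within the scatter), involved hydrogen in place of methoxy at a different place on the shared core, so this methyl position is the first shown where a single small change gives a modest but readable shift. Nothing available gives a reason for this shift.

The compounds shown leave open how the number responds to an ethyl, a fluorine or an amine on this carbon, with only methyl and hydrogen seen there so far. Also open, going by these compounds, is whether hydrogen in place of methyl gives a step of similar size on the core of compound 2.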